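The compounds below may be only part of what the source reports. "The series", "measured", "known", "first", "only" and "open" are said of these compounds alone.

Measured so far:
compound 1, `NS(=O)(=O)N1CCN(c2c(S(=O)(=O)c3cc(F)cc(F)c3)cnc3cc(F)ccc23)CC1` — 6.4%
compound 2, `COc1cccc(S(=O)(=O)c2cnc3cc(F)ccc3c2N2CCC(C)CC2)c1` — 90%

Both were tested in an assay on isolated protein for displacement of a labelled ligand from metabotropic glutamate receptor 5 (Homo sapiens), with a stated time of 60 min, tested at 1 uM; on this read-out lower numbers stand for less inhibition and higher numbers for more inhibition at the one concentration tested (going by the name of the read-out). Compound 2 holds the highest of the two numbers, and its nearest neighbour, compound 1, lies far lower, a gap beyond the scatter. Compound 3, `CC1CCN(c2c(S(=O)(=O)c3cc(F)cc(F)c3)cnc3cc(F)ccc23)CC1`, has not been measured yet. It departs from compound 2 in one place: 3,5-difluorophenyl in place of 3-methoxyphenyl on a sulfonyl sulfur.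

Among the measured compounds shown here, no step between measured compounds shares this change, so the expectation rests on what the two values show. Compound 1 also carries a 3,5-difluorophenyl on its sulfonyl sulfur, and in this assay compound 1 gives 6.4%, yet it differs from compound 3 elsewhere as well, so that low number cannot be laid on the phenyl change alone. The step from compound 2 to compound 3 is expected to be downward, a number 25 percentage points lower from compound 2 to compound 3 (beyond the scatter), most likely beyond the scatter but not to the floor. Compound 3 is estimated at 65%, with a range from 25% to 95%.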

Compound 3, a percentage reported as inhibition, at one concentration (the size of the read-out at that concentration, not a potency): 77%
For compound 3 the middle estimate is 12 percentage points below the measured one; the measured number falls inside the stated range.
By their numbers in this assay, from the lowest: compound 1; then compound 3; then compound 2.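

Replacing 3-methoxyphenyl with 3,5-difluorophenyl on a sulfonyl sulfur gives a number 13 percentage points lower from compound 2 to compound 3 (beyond the scatter) in this assay, so this place accepts the change with a real but modest loss and inhibition stays high. With 3,5-difluorophenyl held constant, 4-methylpiperidin-1-yl in place of 4-sulfamoylpiperazin-1-yl on an aromatic carbon gives a number 70.6 percentage points higher from compound 1 to compound 3 (beyond the scatter), which shows that the low number of compound 1 goes with its 4-sulfamoylpiperazin-1-yl and not with its 3,5-difluorophenyl. Nothing available explains either step.

The compounds shown leave open how an unsubstituted phenyl or a 3-chlorophenyl on the sulfonyl sulfur would fare, and whether a morpholine or an unsubstituted piperazine on that aromatic carbon would stay nearer compound 3 or compound 1. Because each number comes from a single concentration, the potencies of these compounds also remain open.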